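A few compounds are considered here, and "the series" means these few. Any claim that something is new, unique, unknown or untested is made for them only; others in the source may bear on it.

Going by the values given here, compound 3 `CCOC(=O)c1ccc(OC(=O)c2ccc(C(CC)(CC)c3ccc(OCC(=O)C(C)(C)C)c(C)c3)n2CC)cc1` gives 45600 nM in an assay on HL-60 cells for agonist activity at vitamin D3 receptor (Homo sapiens), read by microscopy, with a stated time of 96 h (on this read-out lower numbers stand for an effect already at smaller amounts and higher numbers for an effect only at larger amounts of compound), the highest of the three numbers measured so far. Compound 1 `CCn1c(C(=O)NCCN)ccc1C(CC)(CC)c1ccc(OCC(=O)C(C)(C)C)c(C)c1` gives 120 nM and compound 2 `CCn1c(C(=O)N(C)c2ccccc2)ccc1C(CC)(CC)c1ccc(OCC(=O)C(C)(C)C)c(C)c1` gives 18500 nM in this assay. The steps of a 150-fold higher number from compound 1 to compound 2 (2.19 log units; beyond the scatter) and a 380-fold higher number from compound 1 to compound 3 (2.58 log units; beyond the scatter) were large, both leaving the (2-aminoethyl)amino group behind. Compound 4 `CCn1c(C(=O)OCc2ccc(F)cc2)ccc1C(CC)(CC)c1ccc(OCC(=O)C(C)(C)C)c(C)c1` differs from compound 3 by 4-fluorobenzyl in place of 4-(ethoxycarbonyl)phenyl on an oxygen next to a carbonyl group. Among the compounds with values here, no measured step swaps one ester group for another, so the closest guide is the modest step of a 2.5-fold higher number from compound 2 to compound 3 (0.39 log units; beyond the scatter) between two groups without the amine; a step of similar size, in either direction, is expected in this assay. Compound 4 is therefore estimated at 25000 nM, with a range from 5000 nM to 120000 nM. That estimate means a 1.8-fold lower number from compound 3 to compound 4 (0.26 log units; within the scatter).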

Compound 4, half-maximal effective concentration: 9500 nM
Compound 4: middle estimate off by 2.6-fold (0.42 log units), on the high side; the measured number falls inside the stated range.
By their numbers in this assay, from the lowest: compound 1; then compounds 4 and 2 (each within the scatter of the next); then compound 3.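

Exchanging one ester group for another on this oxygen next to a carbonyl group is not neutral: 4-fluorobenzyl in place of 4-(ethoxycarbonyl)phenyl gives a modest shift (a 4.8-fold lower number from compound 3 to compound 4 (0.68 log units; beyond the scatter)). The (4-fluorobenzyl)oxy ester and the methyl(phenyl)amino amide cannot be told apart (a 1.9-fold lower number from compound 2 to compound 4 (0.29 log units; within the scatter)), whereas the large gap from (2-aminoethyl)amino persists with this ester too (a 79-fold higher number from compound 1 to compound 4 (1.90 log units; beyond the scatter)). No evidence at hand bears on these differences. On these data alone, whether a free carboxylic acid on this carbonyl carbon would sit with the esters remains open. So does whether a longer chain ending in an amine would keep the low number of compound 1.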